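A few compounds are considered here, and "the series" means these few. Any claim that something is new, unique, unknown or untested is made for them only; others in the source may bear on it.

Working notes on the series. In a functional assay on HUVEC cells (Homo sapiens) for inhibition, using NADPH, with a stated time of 2 h (on this read-out lower numbers stand for stronger inhibition and higher numbers for weaker inhibition), compound 2 `Cc1c(COc2cccc(OCC3CCOCC3)c2)[nH]c2ccc(Cl)cc2c1=O` gives 5 nM, the lowest of the three numbers recorded. Compound 3 `Cc1c(COc2cncc(OCCC(C)(C)O)c2)[nH]c2ccccc2c1=O` gives 330 nM in this assay, and compound 1 `COCCOCCCCc1[nH]c2ccccc2c(=O)c1C` gives 460 nM; both gaps to compound 2 lie beyond the scatter, so compound 2 is the most potent of the three. The next compound, compound 4 `Cc1c(COc2cccc(OCC3CCOCC3)c2)[nH]c2ccc(C(=O)O)cc2c1=O`, differs from compound 2 in one place: carboxy in place of chloro on an aromatic carbon. Among the measured compounds shown here, no measured pair shows this change, so the step has no precedent here. The step from compound 2 to compound 4 is expected to be a moderate rise, a 16-fold higher number from compound 2 to compound 4 (1.20 log units; beyond the scatter), rather than none. Compound 4 is therefore estimated at 80 nM, with a range from 12 nM to 600 nM.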

Compound 4, half-maximal inhibitory concentration: 400 nM
Compound 4: the middle estimate sits 5.0-fold (0.70 log units) below what was measured; measured number inside the range.
By their numbers in this assay, from the lowest: compound 2; then compounds 3, 4 and 1 (each within the scatter of the next).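

In this assay, among the compounds shown here, carboxy in place of chloro on this aromatic carbon gives an 80-fold higher number from compound 2 to compound 4 (1.90 log units; beyond the scatter), the first step that can be read at a single position. The position is therefore sensitive to this exchange, with the rest of the structure unchanged. No available evidence accounts for the size of the step. Only chloro and carboxy are shown here, so it remains open how a methyl ester, a primary amide or an amine would read at this carbon. Going by these compounds, the change is also seen on only one side chain, so its size on other side chains remains open.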